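Methylating the Selenium of Compound 2

This account rests on a few compounds, and the source may have more. Where it says the series, first, only, none or still open, it means among the compounds named here.

Compound 2 `Nc1nc([SeH])nc2ncccc12` gives the highest of the three numbers measured in a functional assay on MCF7 cells (Homo sapiens) for cytotoxicity, read by MTT assay, with a stated time of 72 h (a lower number here means a stronger inhibitor of growth, a higher number a weaker inhibitor of growth), where compound 2 gives 37300 nM. Compound 1 `Sc1nc(NCc2ccccc2)c2ccccc2n1` gives 27200 nM, a value within the scatter of that of compound 2, and compound 3 `[SeH]c1nc([SeH])c2cccnc2n1` gives 9830 nM. Within the data shown here, the only measured step, a 3.8-fold lower number from compound 2 to compound 3 (0.58 log units; beyond the scatter), exchanges an atom on the ring and does not touch the selenium. Compound 4 `C[Se]c1nc(N)c2cccnc2n1` differs from compound 2 by methyl in place of hydrogen on a selenium. Among the measured compounds shown here, no measured step bears on this change, so nothing here points to a move beyond the scatter in this assay in either direction. The step of a 1.2-fold lower number from compound 2 to compound 4 (0.09 log units; within the scatter) that the estimate means is expected to be small. Compound 4 is estimated at 30000 nM, with a range from 10000 nM to 90000 nM.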

Compound 4, concentration for 50% growth inhibition: 43000 nM
Compound 4: middle estimate off by 1.4-fold (0.16 log units), on the low side; low and high end bracket the measured number.
By their numbers in this assay, from the lowest: compound 3; then compounds 1, 2 and 4 (each within the scatter of the next).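

In this assay, among these compounds, the selenium hydrogen gives way to methyl with a 1.2-fold higher number from compound 2 to compound 4 (0.06 log units; within the scatter) and this is the first reading at this position, since the earlier step to compound 3 left the selenium untouched. On this core, then, a methyl on the selenium leaves compound 4 level with compound 2 within the scatter. No measurement shown offers an explanation for this result. From the compounds shown here alone, whether a longer chain, such as propyl, or a chain ending in a carboxylic acid would stay level on this selenium remains open. So does whether methyl behaves alike on the selenium of compound 3.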